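Swapping Ethoxy for Fluoro: What to Expect of Compound 4

This account rests on a few compounds, and the source may have more. Where it says the series, first, only, none or still open, it means among the compounds named here.

Compound 1, `CCc1ccc(NC(=O)Nn2c(-c3ccccc3)nc3ccccc3c2=O)cc1`, gives 61% in a functional assay on the whole organism (strain albino) with Mus musculus as the target, at a dose of 100 mg/kg by the intraperitoneal route; a lower number here means less inhibition, a higher number more inhibition at the dose given (going by the name of the read-out).
Compound 2, `O=C(Nc1ccc(Cl)cc1)Nn1c(-c2ccccc2)nc2ccccc2c1=O`, gives 55%.
Compound 3, `CCOc1ccc(NC(=O)Nn2c(-c3ccccc3)nc3ccccc3c2=O)cc1`, gives 53%.

Compound 3 has the lowest of the three numbers, yet its distance to the others is small: a number 8 percentage points lower from compound 1 to compound 3 (within the scatter) and a number 2 percentage points lower from compound 2 to compound 3 (within the scatter). Compound 4, `O=C(Nc1ccc(F)cc1)Nn1c(-c2ccccc2)nc2ccccc2c1=O`, keeps the shared core and changes only the group at one place: fluoro in place of ethoxy on an aromatic carbon. Every measured step here swaps the group at this same place, and each stayed within the scatter: a number 6 percentage points lower from compound 1 to compound 2 (within the scatter), a number 8 percentage points lower from compound 1 to compound 3 (within the scatter), a number 2 percentage points lower from compound 2 to compound 3 (within the scatter). Nothing in these three compounds suggests that a fluoro group would behave differently, so in this assay the expected step is a number 2 percentage points higher from compound 3 to compound 4 (within the scatter). Compound 4 is therefore estimated at 55%, with a range from 40% to 70%.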

Compound 4, a percentage reported as inhibition, in the whole organism at one dose (the size of the read-out at that dose, not a potency): 54%
Compound 4: the middle estimate sits 1 percentage points above what was measured, and the stated range covers the measured number.
By their numbers in this assay, from the lowest: compounds 3, 4, 2 and 1 (each within the scatter of the next).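

With fluoro in the series, the ethyl, chloro, ethoxy and fluoro compounds all lie within the scatter of one another in this assay: a number 1 percentage points higher from compound 3 to compound 4 (within the scatter), a number 1 percentage points lower from compound 2 to compound 4 (within the scatter) and a number 7 percentage points lower from compound 1 to compound 4 (within the scatter). Replacing ethoxy with fluoro removes the hydrogen-bond acceptor counted for that group, and the number still does not move beyond the scatter. Nothing available explains this result.

On these data alone, it remains open whether a different group at this place, such as an amine, a carboxylic acid or a longer chain, would move the number beyond the scatter. The compounds shown also leave open whether these four would stay this close at other doses.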